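A Nitrile Replaces Two Methyl Groups on the Aryl Ether

The compounds below may be only part of what the source reports. "The series", "measured", "known", "first", "only" and "open" are said of these compounds alone.

Within the data shown here, compound 2 `Cc1cc(C)cc(COc2ccc(-c3cc(CN4CCN(Cc5ccc(C(F)(F)F)cc5)CC4)no3)cc2)c1` holds the lowest number of the two compounds measured so far: in a functional assay on Huh-7 cells (Homo sapiens) for antiproliferative activity, read by sulforhodamine B assay, with a stated time of 72 h (a lower number here means a stronger inhibitor, a higher number a weaker inhibitor), compound 2 gives 600 nM. Among the measured compounds shown here, its only neighbour, compound 1 `FC(F)(F)c1ccc(CN2CCN(Cc3cc(-c4ccc(OCc5ccccc5)cc4)on3)CC2)cc1`, carries phenyl where compound 2 carries 3,5-dimethylphenyl, and in this assay compound 1 gives 1700 nM, the step being a 2.8-fold lower number from compound 1 to compound 2 (0.45 log units; beyond the scatter). Compound 3 `N#Cc1ccc(COc2ccc(-c3cc(CN4CCN(Cc5ccc(C(F)(F)F)cc5)CC4)no3)cc2)cc1` has not yet been measured. It differs from compound 2 by 4-cyanophenyl in place of 3,5-dimethylphenyl on a saturated chain carbon bound to an oxygen on an aromatic ring. For the measured compounds named here, the single measured step bears on this only indirectly: it records what happened when phenyl became 3,5-dimethylphenyl at this position, whereas compound 3 gives up that 3,5-dimethylphenyl and brings in a nitrile-bearing ring, for which no measured comparison exists. Compound 3 is therefore expected to drift back toward the number of compound 1, with an expected step of a 2.0-fold higher number from compound 2 to compound 3 (0.30 log units; within the scatter) and an estimated value of 1200 nM, lying between 400 nM and 4000 nM.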

Compound 3, half-maximal inhibitory concentration: 1000 nM
The estimate for compound 3 lay 1.2-fold (0.08 log units) above the measured number; the measured number falls inside the stated range.
By their numbers in this assay, from the lowest: compounds 2, 3 and 1 (each within the scatter of the next, the first and the last beyond it).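

In this assay, 4-cyanophenyl in place of 3,5-dimethylphenyl gives a 1.7-fold higher number from compound 2 to compound 3 (0.22 log units; within the scatter) at this position, and cyano in place of hydrogen on an aromatic carbon gives a 1.7-fold lower number from compound 1 to compound 3 (0.23 log units; within the scatter) on the phenyl ring of compound 1. Neither step leaves the scatter, so compound 3 cannot be told apart from either neighbour, although compound 1 and compound 2 remain separated by a 2.8-fold lower number from compound 1 to compound 2 (0.45 log units; beyond the scatter) in the same assay. A ring bearing a nitrile at this place therefore reads the same as both the plain phenyl and the 3,5-dimethylphenyl ring within the scatter.

From the compounds shown here alone, how a methoxy group, a chlorine atom or a carboxylic acid on this ring would read stays open. No evidence here explains these numbers.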